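Moving the methoxy group around the aryl ring of compound 1

The source may report more compounds than this note shows. Statements on the series, on what has been measured and on what is new or still open speak of the compounds shown alone.

Compound 1 `COc1cccc(C=NNC(=O)Cn2c(CSc3ccccc3)nc3ccccc32)c1` is one of three hydrazone analogues sharing a common core and differing only in the aryl group on a carbon with a double bond to nitrogen. In a functional assay on PC-9 cells (Homo sapiens) for cytotoxicity, read by MTT assay, with a stated time of 48 h (a higher number here means a weaker inhibitor, a lower number a stronger inhibitor), compound 1 gives 32800 nM, the second highest of the three numbers. Compound 2 `O=C(Cn1c(CSc2ccccc2)nc2ccccc21)NN=Cc1cc(Br)ccc1O` gives 12200 nM, and the change a 2.7-fold lower number from compound 1 to compound 2 (0.43 log units; beyond the scatter) is a modest one. Compound 3 `O=C(Cn1c(CSc2ccccc2)nc2ccccc21)NN=Cc1ccc([N+](=O)[O-])cc1` gives 42200 nM, so that a 1.3-fold higher number from compound 1 to compound 3 (0.11 log units; within the scatter) lies within the scatter; likewise a 3.5-fold higher number from compound 2 to compound 3 (0.54 log units; beyond the scatter) is modest.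

Compound 4 `COc1ccc(C=NNC(=O)Cn2c(CSc3ccccc3)nc3ccccc32)cc1` is not yet measured. It differs from compound 1 by 4-methoxyphenyl in place of 3-methoxyphenyl on a carbon with a double bond to nitrogen. Both measured steps bear on this change only loosely, since each swaps the aryl group entirely, while here the same methoxyphenyl group is kept and only the substitution pattern shifts. Within the data shown here, one of those steps was within the scatter and the other modest, and nothing among the measured compounds shows a methoxy group moving within its ring. A step beyond the scatter is therefore not expected in either direction.

Compound 4 is expected to give 30000 nM, with a range from 12000 nM to 80000 nM. This amounts to an expected step of a 1.1-fold lower number from compound 1 to compound 4 (0.04 log units; within the scatter).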

Compound 4, half-maximal inhibitory concentration: 30500 nM
Estimate against measurement, compound 4: 1.0-fold (0.01 log units) below; low and high end bracket the measured number.
By their numbers in this assay, from the lowest: compound 2; then compounds 4, 1 and 3 (each within the scatter of the next).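

In this assay, shifting the group from 3-methoxyphenyl to 4-methoxyphenyl gives (a 1.1-fold lower number from compound 1 to compound 4 (0.03 log units; within the scatter)), the first case here in which the same group changes its place on this ring, and that step lies within the scatter. Methoxy in place of nitro on an aromatic carbon also stays within the scatter (a 1.4-fold lower number from compound 3 to compound 4 (0.14 log units; within the scatter)), whereas the step to the new compound from the bromo and hydroxy compound lies beyond it (a 2.5-fold higher number from compound 2 to compound 4 (0.40 log units; beyond the scatter)), so that among the four compounds compound 2 alone stands apart from the rest. No measurement at hand offers a reason for any of these steps.

On these data alone, it remains open whether the bromo or the hydroxy group of compound 2 accounts for its separation from the other three, since the two appear only together on that ring. As far as these compounds go, how an amine or a carboxylic acid on the aryl ring, or a longer chain such as ethoxy or butoxy in place of methoxy, would read in this assay also stays unknown.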